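Chloro for amino on the shared core

The source may hold more compounds than are shown below. What is called first, only, known or untested is meant among the compounds shown, and "the series" means these compounds.

Compound 1 `COc1ccccc1-c1cc(=O)c2ccc(OC)c(OC)c2o1`: 4 ug/mL
Compound 2 `Nc1c(-c2ccccc2)oc2ccc(Cl)cc2c1=O`: > 100 ug/mL

In a functional assay on KB cells (Homo sapiens) for cytotoxicity (on this read-out lower numbers stand for an effect already at smaller amounts and higher numbers for an effect only at larger amounts of compound), compound 1 gives 4 ug/mL. For compound 2 this assay reports only > 100 ug/mL, which is a limit of the assay and not a number. Compound 2 therefore stands at the limit of > 100 ug/mL in this assay, at which 1 of the 2 values shown sits, the upper edge of the two values shown. Among the measured compounds shown here, compound 1 and compound 2 differ in more than one place, so no step between them is computed and their two values are taken only as they stand.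

Compound 3 `O=c1c(Cl)c(-c2ccccc2)oc2ccc(Cl)cc12` is not yet measured in this assay. It differs from compound 2 as follows: chloro in place of amino on an aromatic carbon. For the measured compounds named here, with compound 2 sitting at a limit, no measured step gives a footing for the size of this change. The expectation is a step of no more than the usual scatter, in either direction, with a fair chance that this assay again reports only a limit. Compound 3 is estimated at 70 ug/mL in this assay, with a range from 15 ug/mL to 300 ug/mL. The expected step is an at least 1.4-fold lower number from compound 2 to compound 3 (0.15 log units; that floor lies within the scatter).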

Compound 3, concentration for half-maximal effect: > 100 ug/mL
Compound 3: only a limit was reported; the forecaster's own chance of this, stated with the estimate: 45%; middle value at least 1.4-fold (0.15 log units) from the limit.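

In this assay, among the compounds shown here, compound 2 and compound 3 both carry only a limit and not a number, so no step between them can be read: the limit of > 100 ug/mL in this assay, at which 2 of the 3 values shown sit. The compounds shown leave open whether chloro in place of amino on an aromatic carbon changes the read-out at all, and in which direction.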